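Bromo substitution on the lactam analogue of the series

A few compounds are considered here, and "the series" means these few. Any claim that something is new, unique, unknown or untested is made for them only; others in the source may bear on it.

Measured compounds in a functional assay on L1210 cells (Mus musculus) for cytotoxicity, with a stated time of 48 h; a higher number here means a weaker inhibitor, a lower number a stronger inhibitor:
- compound 1 `C=C1C(=O)OC(c2ccccc2)C1C` gives 4000 nM; 28000 nM (2 entries)
- compound 2 `C=C1C(=O)OC(c2ccc(OC)cc2)C1C` gives 14200 nM; 3650 nM (2 entries)
- compound 3 `C=C1CC(c2ccccc2)N(C)C1=O` gives > 50000 nM

The two lactones, compound 1 and compound 2, each carry two entries that sit far apart, as the several entries of compound 1 in this assay, 4000 nM; 28000 nM (2 entries) and the several entries of compound 2 in this assay, 14200 nM; 3650 nM (2 entries) show; the values of the two compounds overlap, and no order between them can be read from these numbers. Compound 3, the lactam with a methyl on nitrogen, stands at a limit of this assay rather than at a number, (the limit of > 50000 nM in this assay, at which 1 of the 3 values shown sits), and two further entries for compound 3 give no single number either. Compound 3 is therefore the weakest point of the set as far as the numbers go, though its distance from compound 1 and compound 2 cannot be sized.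

Compound 4 `C=C1CC(c2ccc(Br)cc2)N(C)C1=O` is the next compound, not yet measured in this assay. It differs from compound 3 by bromo in place of hydrogen on an aromatic carbon, the bromine entering para to a group of 8 heavy atoms. Among the compounds with values here, no measured pair in the set shows the effect of a halogen on the aromatic ring, so the size of this step is unknown.

Starting from a limit, no shift beyond the scatter is expected in this assay. The step from compound 3 to compound 4 is estimated at a step that the limit leaves unreadable from compound 3 to compound 4. Compound 4 is expected at 60000 nM, with a range from 20000 nM to 200000 nM, and the assay may well report only a limit again.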

Compound 4, half-maximal inhibitory concentration: > 50000 nM
Compound 4 ended at the assay's limit; the forecaster's own chance of this, stated with the estimate: 65%; the middle value does not contradict the limit.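

Compound 3 and compound 4 both stand at a limit of this assay, and the step of bromo in place of hydrogen on an aromatic carbon between them cannot be read. The compounds shown leave open what this replacement does to cytotoxicity in any compound that gives a number rather than a limit.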